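Methyl to isopropyl on compound 3

The source may report more compounds than this note shows. Statements on the series, on what has been measured and on what is new or still open speak of the compounds shown alone.

Within the data shown here, in an ADME assay on HeLa cells (Homo sapiens) for cytotoxicity, read by MTT assay, with a stated time of 2 days (on this read-out lower numbers stand for higher toxicity in this test and higher numbers for lower toxicity in this test), compound 3 `CNC(=O)c1cc(Oc2ccc3c(C)c(C(=O)OC)sc3c2)ccn1` gives 15700 nM as the lowest number so far. Compound 2 `CNC(=O)c1cc(Oc2ccc3cc(C(=O)OC(C)C)sc3c2)ccn1` gives 45000 nM as the nearest value. Compound 1 `CCOC(=O)c1sc2cc(Oc3ccnc(C(=O)NC)c3)ccc2c1C` gives > 100000 nM as a limit of the assay and not a number. Compound 4 `CNC(=O)c1cc(Oc2ccc3c(C)c(C(=O)OC(C)C)sc3c2)ccn1` carries isopropyl in place of methyl on an oxygen next to a carbonyl group and has no value yet. Among the measured compounds shown here, the step of an at least 6.3-fold lower number from compound 1 to compound 3 (0.80 log units; beyond the scatter) bears on this as the only measured change of the chain on that oxygen, and there the smaller group went with the lower number. The change to compound 4 runs the other way, so a rise beyond the scatter is expected, with an estimated 3.2-fold higher number from compound 3 to compound 4 (0.50 log units; beyond the scatter) in this assay for this change. The expected value of compound 4 is 50000 nM with a range from 20000 nM to 100000 nM as estimated.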

Compound 4, half-maximal cytotoxic concentration: 9600 nM
For compound 4 the middle estimate is 5.2-fold (0.72 log units) above the measured one; the whole stated range lies above it.
By their numbers in this assay, from the lowest: compounds 4 and 3 (each within the scatter of the next); then compound 2. At a limit, above all of these: compound 1.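

Swapping methyl for isopropyl on this oxygen gives a 1.6-fold lower number from compound 3 to compound 4 (0.21 log units; within the scatter), so the earlier link between a smaller chain and a lower number does not extend to this change, and compound 4 goes against it. With the isopropyl ester held in place, the methyl on the aromatic carbon goes with a 4.7-fold lower number from compound 2 to compound 4 (0.67 log units; beyond the scatter), a clearer step. The third step, an at least 10-fold lower number from compound 1 to compound 4 (1.01 log units; beyond the scatter), rests on compound 1, whose entry is a limit and not a number: the limit of > 100000 nM in this assay, at which 1 of the 4 values shown sits.

Going by these compounds, a carboxylic acid in place of the ester, or a longer chain on that oxygen, remains open.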